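The compounds below may be only part of what the source reports. "The series", "measured", "known", "first", "only" and "open" are said of these compounds alone.

Compound 2, `Cc1cccc(-c2nnc(COc3cnn(C(C)(C)C)c(=O)c3Cl)s2)c1`, stands only at a limit: in a functional assay on the whole organism for inhibition, with Mythimna separata as the target, with a stated time of 5 days (a higher number here means that more compound is needed for the effect, a lower number that less compound is needed), compound 2 gives > 300 ug/mL, which is a limit of the assay and not a number (the limit of > 300 ug/mL in this assay, at which 1 of the 2 values shown sits). Compound 1, `CC(C)(C)n1ncc(OCc2nnc(-c3ccc(Cl)cc3)s2)c(Cl)c1=O`, carries a 4-chlorophenyl where compound 2 carries a 3-methylphenyl, and in this assay compound 1 gives 106 ug/mL. For the measured compounds named here, the only measured step, an at least 2.8-fold higher number from compound 1 to compound 2 (0.45 log units; beyond the scatter), is thus the one that bears on what follows. Compound 3, `CC(C)(C)n1ncc(OCc2nnc(-c3ccc(F)cc3)s2)c(Cl)c1=O`, differs from compound 2 by 4-fluorophenyl in place of 3-methylphenyl on an aromatic carbon. The 4-fluorophenyl that enters is a close relative of the 4-chlorophenyl of compound 1, so the change is expected to undo the loss seen in the measured step. The step is therefore expected to lower the number beyond the scatter, estimated as an at least 2.0-fold lower number from compound 2 to compound 3 (0.30 log units; that floor lies within the scatter). Compound 2 offers only a limit, and the size of that drop cannot be fixed closely from it. Compound 3 is expected to give roughly 150 ug/mL in this assay, with a range from 60 ug/mL to 400 ug/mL.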

Compound 3, half-maximal effective concentration: 21.5 ug/mL
For compound 3 the middle estimate is 7.0-fold (0.84 log units) above the measured one; measured number outside the range, below it.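

In this assay the aromatic carbon of the five-membered ring proves far more sensitive to the choice of phenyl group than the first step could show, since the exchange of 3-methylphenyl for 4-fluorophenyl gives an at least 13-fold lower number from compound 2 to compound 3 (1.14 log units; beyond the scatter) and this size is only a floor. The exchange of fluoro for chloro gives a 4.9-fold lower number from compound 1 to compound 3 (0.69 log units; beyond the scatter) and so shows that the two halogen-bearing phenyl groups are not interchangeable here, with compound 3 carrying the lowest number of the three, and its steps to both others lie beyond the scatter. As far as these compounds go, the value of compound 2 is a limit of the assay and not a number, so the true size of the larger step stays unknown: the limit of > 300 ug/mL in this assay, at which 1 of the 3 values shown sits.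

The compounds shown leave open whether compound 2 falls behind for its methyl group or for the place of that group on the phenyl ring, since 3-methylphenyl differs from the two halogen-bearing groups in both respects. They also leave open how a methoxy group, an amine or a carboxylic acid on that phenyl ring would fare in this assay when set against the 4-fluorophenyl of compound 3.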